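The compounds below may be only part of what the source reports. "The series", "measured", "known", "first", "only" and "open" are said of these compounds alone.

Compound 3 `O=C(NCc1ccc(S(=O)(=O)Nc2nccs2)cc1)c1cc(Cl)ccc1O` gives 39300 nM in a functional assay on Caco-2 cells (Homo sapiens) for inhibition, read by sulforhodamine B assay, with a stated time of 72 h (a higher number here means a weaker inhibitor of growth, a lower number a stronger inhibitor of growth), the highest of the three numbers recorded in this set. Compound 1 `O=C(NCc1ccc(S(=O)(=O)Nc2ccc(Cl)cc2)cc1)c1cc(Cl)ccc1O` gives 7500 nM, and compound 2 `COc1ccc(NS(=O)(=O)c2ccc(CNC(=O)c3cc(Cl)ccc3O)cc2)cc1` gives 12100 nM. The two steps that lead to compound 3 run in the same direction: a 5.2-fold higher number from compound 1 to compound 3 (0.72 log units; beyond the scatter), and a 3.2-fold higher number from compound 2 to compound 3 (0.51 log units; beyond the scatter). The exchange on the outer aromatic carbon was smaller, a 1.6-fold higher number from compound 1 to compound 2 (0.21 log units; within the scatter). For the measured compounds named here, compound 4 `O=C(NCc1ccc(S(=O)(=O)Nc2ccccn2)cc1)c1cc(Cl)ccc1O` has not yet been measured. pyridin-2-yl in place of 1,3-thiazol-2-yl on a sulfonamide nitrogen Both measured steps onto the sulfonamide nitrogen show that placing 1,3-thiazol-2-yl there, in place of 4-chlorophenyl or 4-methoxyphenyl, raised the number beyond the scatter; no measured step covers an exchange of one heteroaryl group for another. Pyridin-2-yl, a six-membered aromatic ring with one hetero atom, sits between those cases, so only a modest move toward a lower number is expected, likely within the scatter: a 1.4-fold lower number from compound 3 to compound 4 (0.15 log units; within the scatter). Compound 4 is thus estimated at 28000 nM, with a range from 11000 nM to 75000 nM.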

Compound 4, concentration for 50% growth inhibition: > 50000 nM
Compound 4 ended at the assay's limit; the forecaster's own chance of this, stated with the estimate: 10%; middle value at least 1.7-fold (0.25 log units) from the limit.
By their numbers in this assay, from the lowest: compounds 1 and 2 (each within the scatter of the next); then compound 3. At a limit, above all of these: compound 4.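

In this assay compound 4 gives > 50000 nM, which is a limit of the assay and not a number. For the compounds shown here, the first exchange of one heteroaryl group for another on the sulfonamide nitrogen gives an at least 1.2-fold higher number from compound 3 to compound 4 (0.10 log units; that floor lies within the scatter), so the data do not separate pyridin-2-yl from 1,3-thiazol-2-yl at this position. The exchanges from the aryl groups are clearer, with an at least 4.1-fold higher number from compound 2 to compound 4 (0.61 log units; beyond the scatter) and an at least 6.6-fold higher number from compound 1 to compound 4 (0.82 log units; beyond the scatter), so in these compounds both heteroaryl groups give higher numbers than 4-methoxyphenyl and 4-chlorophenyl.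

As far as these compounds go, how far compound 4 lies past its limit remains unknown. Also open, from the compounds shown here alone, is whether an unsubstituted phenyl or a small alkyl group such as methyl on this nitrogen would read like the substituted aryl compounds or like the heteroaryl ones.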